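The compounds below may be only part of what the source reports. "The series", "measured", "known", "first", "only" and "open" are said of these compounds alone.

Notes on the series. Compound 1 `Cc1cc(OCCCCCCC[N+]2(C)CCCCC2)cc(-n2cc(C(=O)Nc3cc(F)cc(F)c3)c(=O)c3ccc(N(C)C)nc32)c1` gives 79.7% in an assay on LX2 cells for inhibition of COL1A1 promoter (Homo sapiens), read by a luciferase reporter, with a stated time of 24 h, tested at 50 uM; a higher number here means a stronger effect of the compound at the concentration tested, a lower number a weaker effect. Compound 3 `Cc1cc(OCCCCCCC[n+]2ccccc2)cc(-n2cc(C(=O)Nc3cc(F)cc(F)c3)c(=O)c3ccc(N(C)C)nc32)c1` differs from compound 1 by a group of 6 heavy atoms (5 carbon, 1 nitrogen; one six-membered aromatic ring with 1 hetero atom) in place of a group of 7 heavy atoms (6 carbon, 1 nitrogen; one six-membered non-aromatic ring with 1 hetero atom), on a saturated chain carbon, seven bonds along the chain from an oxygen on an aromatic ring; in this assay compound 3 gives 61%, the step being a number 18.7 percentage points lower from compound 1 to compound 3 (beyond the scatter). Compound 2 `Cc1ccc(-n2cc(C(=O)Nc3cc(F)cc(F)c3)c(=O)c3ccc(N(C)C)nc32)cc1OCCCCCCC[N+]1(C)CCCCC1` has the same atoms as compound 1 joined differently; the difference between the two cores is not broken down here. In this assay, within the data shown here, compound 2 gives 45.1%, the lowest of the three numbers so far, with the gaps to compound 3 and to compound 1 both beyond the scatter.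

Compound 4 `Cc1ccc(-n2cc(C(=O)Nc3cc(F)cc(F)c3)c(=O)c3ccc(N(C)C)nc32)cc1OCCCCCCC[n+]1ccccc1` is not yet measured. It differs from compound 2 by a group of 6 heavy atoms (5 carbon, 1 nitrogen; one six-membered aromatic ring with 1 hetero atom) in place of a group of 7 heavy atoms (6 carbon, 1 nitrogen; one six-membered non-aromatic ring with 1 hetero atom), on a saturated chain carbon, seven bonds along the chain from an oxygen on an aromatic ring, the same change as between compound 1 and compound 3. That change has been measured once only, on the core of compound 1, where it gave a number 18.7 percentage points lower from compound 1 to compound 3 (beyond the scatter). Whether the size carries over to the core of compound 2, which starts from a lower value, is not shown by any measured pair. Expected on this basis is a step of a number 15.1 percentage points lower from compound 2 to compound 4 (beyond the scatter), resting on a number 18.7 percentage points lower from compound 1 to compound 3 (beyond the scatter) and on the lower starting point of compound 2 at 45.1%, which leaves less room for a fall of the same size. Compound 4 is accordingly expected to give about 30% in this assay. The likely range for compound 4 is estimated from 10% to 50%.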

Compound 4, a percentage reported as inhibition, at one concentration (the size of the read-out at that concentration, not a potency): 22.2%
Compound 4: the middle estimate sits 7.8 percentage points above what was measured; low and high end bracket the measured number.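

In this assay, putting the six-membered aromatic ring with 1 hetero atom in place of the six-membered non-aromatic ring with 1 hetero atom, on the saturated chain carbon seven bonds along the chain from an oxygen on an aromatic ring, gives a number 22.9 percentage points lower from compound 2 to compound 4 (beyond the scatter), and the earlier step on the other core agrees with it in size: the same change on two cores in this assay, a number 18.7 percentage points lower (beyond the scatter) from compound 1 to compound 3 and a number 22.9 percentage points lower (beyond the scatter) from compound 2 to compound 4, 4.2 percentage points apart, within the scatter of two such steps The change therefore carries over between these two cores as a fall of similar size, and the lower starting value of compound 2 does not make the step measurably different. This rests on one pair of end groups on two cores, read at a single concentration, so it shows neither that the step holds on any other core nor what lies behind it, and it gives no potency.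

Still open, on these data alone, is whether the same step appears with a tertiary amine, a morpholine ring or a trimethylammonium group at the end of the chain, or with a shorter or longer chain. Also open, as far as these compounds go, is whether the two cores keep the same relation at other concentrations in this assay.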